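The source may report more compounds than this note shows. Statements on the series, on what has been measured and on what is new or still open speak of the compounds shown alone.

Compound 1 `COc1ccc(Nc2nc3ccccc3nc2S(=O)(=O)c2ccc(C)cc2)cc1`: in a functional assay on HCT-116 cells (Homo sapiens) for cytotoxicity, read by MTT assay, with a stated time of 72 h (a higher number here means a weaker inhibitor, a lower number a stronger inhibitor), compound 1 gives > 50000 nM, which is a limit of the assay and not a number.
Compound 2 `COc1cc(Nc2nc3ccccc3nc2S(=O)(=O)c2ccc(C)cc2)cc(OC)c1`: in this assay compound 2 gives > 50000 nM, again a limit and not a number.
Going by the values given here, compound 3 `COc1ccc(Nc2nc3ccccc3nc2S(=O)(=O)c2ccc(F)cc2)cc1`: in this assay compound 3 gives 3010 nM, the only number among the three.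

The cores of compound 1 and compound 3 differ by fluoro in place of methyl on an aromatic carbon, and this difference carries an at least 16-fold lower number from compound 1 to compound 3 (1.22 log units; beyond the scatter). The change 3,5-dimethoxyphenyl in place of 4-methoxyphenyl on a nitrogen on an aromatic ring carries a step that the two limits leave unreadable from compound 1 to compound 2, since both values sit at the limit of > 50000 nM in this assay, at which 2 of the 3 values shown sit.

Compound 4 `COc1cc(Nc2nc3ccccc3nc2S(=O)(=O)c2ccc(F)cc2)cc(OC)c1` is not yet measured. It differs from compound 3 by 3,5-dimethoxyphenyl in place of 4-methoxyphenyl on a nitrogen on an aromatic ring, the same change as that from compound 1 to compound 2, made here on the core of compound 3, which already has the fluoro. The size of that change is not readable from compound 1 and compound 2, so the expectation for compound 4 rests on the value of compound 3 alone, with a wide band. For compound 4 a step of a 2.0-fold higher number from compound 3 to compound 4 (0.30 log units; within the scatter) in this assay is expected. Compound 4 is estimated at 6000 nM, with a range from 1500 nM to 40000 nM.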

Compound 4, half-maximal inhibitory concentration: 3930 nM
Beside the measured number, compound 4's estimate is 1.5-fold (0.18 log units) above it, and the stated range covers the measured number.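

On the core of compound 3, 3,5-dimethoxyphenyl in place of 4-methoxyphenyl gives a 1.3-fold higher number from compound 3 to compound 4 (0.12 log units; within the scatter) in this assay, so the two groups cannot be told apart on this core, while the same change on the core of compound 1 cannot be read: the limit of > 50000 nM in this assay, at which 2 of the 4 values shown sit. Fluoro in place of methyl gives an at least 12-fold lower number from compound 2 to compound 4 (1.10 log units; beyond the scatter), a second large step in the same direction as the first: the same change on two cores in this assay, an at least 16-fold lower number (1.22 log units; beyond the scatter) from compound 1 to compound 3 and an at least 12-fold lower number (1.10 log units; beyond the scatter) from compound 2 to compound 4; the limit leaves it open whether they differ. This shows that the drop in the number carries over between the two cores, but it does not show how large the fluoro step truly is on either core, with compound 1 and compound 2 given only as limits.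

As far as these compounds go, it remains open whether chloro or trifluoromethyl in place of the fluoro would keep the lower number. Also open, from the compounds shown here alone, is how an amine or a carboxylic acid on the aromatic ring carried by the nitrogen would read in this assay.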